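The source may report more compounds than this note shows. Statements on the series, on what has been measured and on what is new or still open speak of the compounds shown alone.

Working notes on the series. Compound 1 `O=C(Nc1cccc(-n2cc(-c3ccncc3)c(-c3cc(O)cc(Cl)c3)n2)c1)Nc1ccc(Cl)c(C(F)(F)F)c1` gives 63.4% in a functional assay on COLO 205 cells (Homo sapiens) for inhibition, read by sulforhodamine B assay, with a stated time of 48 h, tested at 10 uM; on this read-out higher numbers stand for a weaker effect at the one concentration tested and lower numbers for a stronger effect. Compound 2 `O=C(Nc1cccc(-n2cc(-c3ccncc3)c(-c3cc(O)cc(Cl)c3)n2)c1)Nc1ccc(Cl)c(Cl)c1` gives 22.4% in this assay; the step is a number 41 percentage points lower from compound 1 to compound 2 (beyond the scatter). Compound 3 `COc1cc(Cl)cc(-c2nn(-c3cccc(NC(=O)Nc4ccc(Cl)c(C(F)(F)F)c4)c3)cc2-c2ccncc2)c1` gives -48.3% in this assay, the lowest of the three numbers, with the step of a number 111.7 percentage points lower from compound 1 to compound 3 (beyond the scatter); its nearest neighbour is compound 2 and the furthest is compound 1.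

Compound 4 `COc1cc(Cl)cc(-c2nn(-c3cccc(NC(=O)c4cccc(C(F)(F)F)c4)c3)cc2-c2ccncc2)c1` is not yet measured. Its change from compound 3 is 3-(trifluoromethyl)phenyl in place of (4-chloro-3-(trifluoromethyl)phenyl)amino on a carbonyl carbon. Neither measured step bears on this position: one exchanges chloro for trifluoromethyl on an aromatic carbon, the other puts methyl in place of hydrogen on an oxygen on an aromatic ring, and both leave the carbonyl and its amino neighbour untouched. The two measured steps were both large, so the read-out has shown itself sensitive to single changes in this series. For the measured compounds named here, with no direct precedent, a step upward is expected, a number 63.3 percentage points higher from compound 3 to compound 4 (beyond the scatter), with wide uncertainty. Compound 4 is therefore estimated to give 15% in this assay, with a range from -35% to 65%.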

Compound 4, a percentage reported as activity, at one concentration (the size of the read-out at that concentration, not a potency): 68.5%
For compound 4 the middle estimate is 53.5 percentage points below the measured one; measured number above the stated range.
By their numbers in this assay, from the lowest: compound 3; then compound 2; then compounds 1 and 4 (each within the scatter of the next).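

The carbonyl carbon is a third place where one change moves the read-out sharply: in this assay, 3-(trifluoromethyl)phenyl in place of (4-chloro-3-(trifluoromethyl)phenyl)amino gives a number 116.8 percentage points higher from compound 3 to compound 4 (beyond the scatter), so the strong effect of compound 3 does not survive this exchange. The change removes the amino nitrogen with its hydrogen-bond donor and also the ring chloro, so this single step cannot assign the shift to either one. No measurement at hand explains the shift.

Still open, on these data alone, is whether the amino nitrogen or the chloro carries the difference, which a 3-(trifluoromethyl)phenylamino group on the same carbonyl carbon would help to separate. Also open, as far as these compounds go, is how a methylene or an ether oxygen in place of that amino nitrogen would read in this assay.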